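Swapping the Ring Nitrogen Cap: Benzoyl to Methylsulfonyl

A few compounds are considered here, and "the series" means these few. Any claim that something is new, unique, unknown or untested is made for them only; others in the source may bear on it.

Measured compounds:
compound 1, `CN(C)c1ccc(C2CC(c3ccc(-n4cncn4)cc3)=NN2S(C)(=O)=O)cc1`, 7.8%;
compound 2, `CN(C)c1ccc(C2CC(c3ccc(-n4ccnc4)cc3)=NN2C(=O)c2ccc(C(F)(F)F)cc2)cc1`, 17.9%.

In a functional assay on MDA-MB-231 cells (Homo sapiens) for inhibition, read by sulforhodamine B assay, tested at 10 uM (on this read-out higher numbers stand for more inhibition at the one concentration tested (going by the name of the read-out) and lower numbers for less inhibition), compound 2 stands highest of the two numbers, and its nearest neighbour is compound 1, which lies lower by a margin beyond the scatter. Compound 3, `CN(C)c1ccc(C2CC(c3ccc(-n4ccnc4)cc3)=NN2S(C)(=O)=O)cc1`, is not yet measured. It differs from compound 2 by methylsulfonyl in place of (4-(trifluoromethyl)phenyl)carbonyl on an amine nitrogen in a ring. Compound 1 also carries methylsulfonyl on that nitrogen and gives 7.8%, so the step of a number 8.9 percentage points lower from compound 2 to compound 3 (within the scatter) is expected to be downward, of modest size near the edge of the scatter. Compound 3 is therefore expected to give about 9%, within 0% to 20%.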

Compound 3, a percentage reported as inhibition, at one concentration (the size of the read-out at that concentration, not a potency): 12%
Estimate against measurement, compound 3: 3 percentage points below; the measured number falls inside the stated range.
By their numbers in this assay, from the lowest: compounds 1, 3 and 2 (each within the scatter of the next, the first and the last beyond it).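

In this assay the step from the (4-(trifluoromethyl)phenyl)carbonyl group, with its aromatic ring, to methylsulfonyl on the ring amine nitrogen is a number 5.9 percentage points lower from compound 2 to compound 3 (within the scatter) and so cannot be told apart from repeat-measurement noise. The exchange of 1H-1,2,4-triazol-1-yl for 1H-imidazol-1-yl on an aromatic carbon gives a number 4.2 percentage points higher from compound 1 to compound 3 (within the scatter) and is equally unresolved, so the gap between compound 1 and compound 2 cannot be pinned on either single change. Nothing available explains these numbers. Open, as far as these compounds go, is whether an acetyl group or a longer alkylsulfonyl chain on that nitrogen would give a step beyond the scatter.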